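The source may report more compounds than this note shows. Statements on the series, on what has been measured and on what is new or still open speak of the compounds shown alone.

Measured so far:
- compound 1 `O=C1COCCN1c1ccc(/N=C\c2c[nH]c3ccccc23)cc1`: 98.5%
- compound 2 `O=C1COCCN1c1ccc(/N=C\c2cn(C(=O)c3ccccc3)c3ccccc23)cc1`: 88.6%
- compound 3 `O=C1COCCN1c1ccc(/N=C\c2cn(C(=O)c3ccc(Cl)cc3)c3ccccc23)cc1`: 90.1%

All three were tested in an ADME assay on BV-2 cells (Mus musculus) for cytotoxicity, read by MTT assay, with a stated time of 48 h, tested at 10 uM (a higher number here means a weaker effect of the compound at the concentration tested, a lower number a stronger effect), and all three leave most of the cells alive. Compound 3 stands second highest of the three numbers; its nearest neighbour is compound 2, and a number 1.5 percentage points higher from compound 2 to compound 3 (within the scatter); its furthest is compound 1, and a number 8.4 percentage points lower from compound 1 to compound 3 (within the scatter). So the three compounds cannot be told apart in this assay.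

Compound 4 `O=C1COCCN1c1ccc(/N=C\c2cn(Cc3ccccc3)c3ccccc23)cc1` is not yet measured. Its change from compound 3 is benzyl in place of (4-chlorophenyl)carbonyl on an aromatic nitrogen. Going by the values given here, two measured steps bear on it. Taking the (4-chlorophenyl)carbonyl off the aromatic nitrogen altogether gave a number 8.4 percentage points lower from compound 1 to compound 3 (within the scatter), and swapping chloro for hydrogen gave a number 1.5 percentage points higher from compound 2 to compound 3 (within the scatter); swapping the whole group for benzoyl gave a number 9.9 percentage points lower from compound 1 to compound 2 (within the scatter). Among the compounds with values here, every change at this position so far left the read-out within the scatter, so no step beyond the scatter is expected from compound 3 to compound 4, and the estimate for that step is a number 0.9 percentage points higher from compound 3 to compound 4 (within the scatter). For compound 4 the expected value in this assay is 91%, with a range from 80% to 100%.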

Compound 4, a percentage reported as activity, at one concentration (the size of the read-out at that concentration, not a potency): 91.3%
For compound 4 the middle estimate is 0.3 percentage points below the measured one, and the stated range covers the measured number.
By their numbers in this assay, from the lowest: compounds 2, 3, 4 and 1 (each within the scatter of the next).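

Going by these compounds alone, until now, every group on this aromatic nitrogen carried a carbonyl, and benzyl is the first without one: the chlorine, the carbonyl oxygen and the hydrogen-bond acceptor all leave, yet in this assay the outcome is a number 1.2 percentage points higher from compound 3 to compound 4 (within the scatter). Without the chlorine as a second difference, the same holds against the benzoyl group, with a number 2.7 percentage points higher from compound 2 to compound 4 (within the scatter), and against the bare hydrogen, with a number 7.2 percentage points lower from compound 1 to compound 4 (within the scatter), so across these four compounds neither the carbonyl nor the group as a whole changes the read-out by more than the usual scatter. Nothing available explains this lack of change.

From the compounds shown here alone, all the groups placed on this nitrogen so far end in a six-membered aromatic ring of carbon only, so it remains open whether an amine, a carboxylic acid or a longer carbon chain in that place would leave the read-out just as unchanged. With a single tested concentration and no value outside the scatter, these compounds also cannot show how the cells would respond at other concentrations.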